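A few compounds are considered here, and "the series" means these few. Any claim that something is new, unique, unknown or untested is made for them only; others in the source may bear on it.

Working notes on the diphosphate series. Compound 1 `O=C(O)CSc1ccn([C@@H]2O[C@H](COP(=O)(O)OP(=O)(O)O)[C@@H](O)[C@H]2O)c(=O)n1` carries a carboxylic acid on the chain bound to sulfur and in an in vitro functional assay on 1321-N1 cells for agonist activity at P2Y purinoceptor 6 (Homo sapiens) (on this read-out higher numbers stand for an effect only at larger amounts of compound and lower numbers for an effect already at smaller amounts), compound 1 gives 1700 nM. Compound 2 `NC(=O)CSc1ccn([C@@H]2O[C@H](COP(=O)(O)OP(=O)(O)O)[C@@H](O)[C@H]2O)c(=O)n1` replaces that acid with an amide; in this assay compound 2 gives 18000 nM, the highest of the two numbers measured, and the step of an 11-fold higher number from compound 1 to compound 2 (1.02 log units; beyond the scatter) is large and well beyond the scatter. The next compound, compound 3 `O=C(O)CCSc1ccn([C@@H]2O[C@H](COP(=O)(O)OP(=O)(O)O)[C@@H](O)[C@H]2O)c(=O)n1`, differs from compound 2 in one place: carboxymethyl in place of carbamoyl on a saturated chain carbon bound to a sulfur. For the measured compounds named here, the only step that bears on this change is an 11-fold higher number from compound 1 to compound 2 (1.02 log units; beyond the scatter), which shows that exchanging the acid for the amide raised the number sharply; reversing that exchange while lengthening the chain is expected to bring the number back down, though not necessarily all the way to compound 1. The expected step to compound 3 is therefore a 6.0-fold lower number from compound 2 to compound 3 (0.78 log units; beyond the scatter). In this assay compound 3 is estimated at 3000 nM, with a range of 800 nM to 12000 nM.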

Compound 3, half-maximal effective concentration: 1100 nM
Estimate against measurement, compound 3: 2.7-fold (0.44 log units) above; low and high end bracket the measured number.
By their numbers in this assay, from the lowest: compounds 3 and 1 (each within the scatter of the next); then compound 2.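

In this assay, the result shows that the high number of compound 2 does not follow from every change at this place on the chain bound to sulfur: a 16-fold lower number from compound 2 to compound 3 (1.21 log units; beyond the scatter) is large and restores an acid on a longer chain. For the compounds shown here, with a 1.5-fold lower number from compound 1 to compound 3 (0.19 log units; within the scatter) within the scatter, carboxy and carboxymethyl at this place cannot be told apart, so the acid tolerates this lengthening of the chain so far. No measurement bearing on the reason for these steps is available.

Open, as far as these compounds go, is whether an amide on the 2-carboxyethyl-length chain would give a number as high as that of compound 2. Also open, from the compounds shown here alone, is whether a still longer chain ending in a carboxylic acid, or a chain ending in a methyl ester or an amine, would hold the number of the two acids.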